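Chloro on the benzyl ring of compound 2

The compounds below may be only part of what the source reports. "The series", "measured", "known", "first", "only" and "open" are said of these compounds alone.

Compound 1 `Nc1sc2c(c1C(=O)NNc1ccccc1)CCCCCC2` was run in a functional assay on CHO cells for agonist activity at adenosine receptor A1 (Homo sapiens), read by ERK phosphorylation, tested at 3 uM (a lower number here means a weaker effect, a higher number a stronger effect of the compound at the concentration tested), and gives 47%. Compound 2 `Nc1sc2c(c1C(=O)NCc1ccccc1)CCCCCC2` gives 48% in this assay. For the measured compounds named here, the single measured step, a number 1 percentage points higher from compound 1 to compound 2 (within the scatter), shows that exchanging the group on the amide-type nitrogen left the read-out unchanged within the scatter; compound 2 and compound 1 therefore lie within the scatter of each other, and compound 2 is the point of departure for the next step.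

Compound 3 `Nc1sc2c(c1C(=O)NCc1cccc(Cl)c1)CCCCCC2` differs from compound 2 by chloro in place of hydrogen on an aromatic carbon. Going by the values given here, no measured step adds a substituent to the six-membered aromatic ring; the step from compound 1 to compound 2 bears on the question only in showing that a change in the part of the molecule carried on the amide-type nitrogen did not move the read-out beyond the scatter in this assay. Among the compounds with values here, that is the sole guide, so no step beyond the scatter is expected for compound 3 in either direction, with a wide range because a direct precedent is lacking.

Compound 3 is accordingly estimated at 50% in this assay, within 33% to 67%. This estimate means an expected step of a number 2 percentage points higher from compound 2 to compound 3 (within the scatter), staying within the scatter.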

Compound 3, a percentage reported as activity, at one concentration (the size of the read-out at that concentration, not a potency): 49%
Compound 3: the middle estimate sits 1 percentage points above what was measured; low and high end bracket the measured number.
By their numbers in this assay, from the lowest: compounds 1, 2 and 3 (each within the scatter of the next).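

In this assay, the change from phenyl to 3-chlorophenyl gives a number 1 percentage points higher from compound 2 to compound 3 (within the scatter). For the compounds shown here, this is the first substitution on the six-membered aromatic ring, whereas the earlier step concerned only the group carried on the amide-type nitrogen, and it shows that a chlorine atom at this position, meta to a large group, leaves the read-out within the scatter at the single concentration tested. No available evidence bears on this result.

From the compounds shown here alone, it remains open whether another group at this position, such as an amine, a carboxylic acid or a longer alkyl chain, would shift the read-out in this assay beyond the scatter, and whether chloro on another carbon of the same ring would behave like the 3-chlorophenyl group. The read-out comes from one concentration, so the values also leave open whether compound 2 and compound 3 would show a similar effect at other concentrations.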